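Aryl swap on the triazole nitrogen: compound 3 to compound 4

This account rests on a few compounds, and the source may have more. Where it says the series, first, only, none or still open, it means among the compounds named here.

Three members of the series have been read in an ADME assay on L02 cells (Homo sapiens) for antiproliferative activity, read by MTT assay, with a stated time of 48 h; on this read-out higher numbers stand for weaker inhibition and lower numbers for stronger inhibition. Compound 1 `CCc1ccccc1-n1nncc1CN1C(=O)C2(C(C#N)=C(N)Oc3c(N)cc4nc5ccccc5nc4c32)c2ccccc21` gives 22900 nM. Compound 2 `N#CC1=C(N)Oc2c(N)cc3nc4ccccc4nc3c2C12C(=O)N(Cc1cnnn1-c1ccc([N+](=O)[O-])cc1)c1ccccc12` returns only a limit of the assay, > 50000 nM. Compound 3 `N#CC1=C(N)Oc2c(N)cc3nc4ccccc4nc3c2C12C(=O)N(Cc1cnnn1-c1ccc(Cl)cc1Cl)c1ccccc12` likewise returns only a limit of the assay, > 50000 nM. The steps from the ethyl-bearing parent are an at least 2.1-fold higher number from compound 1 to compound 2 (0.33 log units; beyond the scatter) and an at least 2.1-fold higher number from compound 1 to compound 3 (0.33 log units; beyond the scatter); between the two limit compounds the step is a step that the two limits leave unreadable from compound 2 to compound 3, and the common feature is the limit of > 50000 nM in this assay, at which 2 of the 3 values shown sit. Compound 3 therefore stands at the weak end of what is shown, with no number of its own.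

Compound 4 `Cc1ccc(Cl)cc1-n1nncc1CN1C(=O)C2(C(C#N)=C(N)Oc3c(N)cc4nc5ccccc5nc4c32)c2ccccc21` is the next step: 5-chloro-2-methylphenyl in place of 2,4-dichlorophenyl on an aromatic nitrogen. Both aryl exchanges measured so far moved the number upward beyond the scatter, and compound 3 itself sits at the limit, so for compound 4 no strong return toward the value of compound 1 is expected; the estimated step is an at least 1.2-fold lower number from compound 3 to compound 4 (0.09 log units; that floor lies within the scatter). The estimate for compound 4 in this assay is 40000 nM, within 15000 nM to 90000 nM, with a fair chance that only a limit is reported again.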

Compound 4, half-maximal inhibitory concentration: > 50000 nM
Compound 4: only a limit was reported; the forecaster's own chance of this, stated with the estimate: 50%; middle value at least 1.2-fold (0.09 log units) away from the limit.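

In this assay the change of aryl group gives an at least 2.1-fold higher number from compound 1 to compound 4 (0.33 log units; beyond the scatter), so an alkyl group on the aryl ring, here the methyl of 5-chloro-2-methylphenyl, is not enough to keep a readable number. Of the four aryl groups shown, only the 2-ethylphenyl of compound 1 gives a number, and the readings now gather at one ceiling: the limit of > 50000 nM in this assay, at which 3 of the 4 values shown sit. The steps from compound 2 and from compound 3 to compound 4 cannot be read, as both ends of each are limits.

Open, from the compounds shown here alone, is whether the number of compound 1 depends on the ethyl group itself or on the ring carrying no chlorine or nitro group, which plain phenyl or 2-methylphenyl would separate. Also open, going by these compounds, is how an aryl ring bearing an amine or a carboxylic acid would read.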